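The source may report more compounds than this note shows. Statements on the series, on what has been measured and on what is new or still open speak of the compounds shown alone.

Compound 1 `Cc1ccc(S(=O)(=O)Nc2ccc3oc(-c4ccccc4)nc3c2)cc1` carries a 4-methylphenyl on the sulfonyl sulfur of the shared core. In an assay on cells for inhibition of HSP60/HSP10 (Homo sapiens), with a stated time of 60 min (a higher number here means a weaker inhibitor, a lower number a stronger inhibitor), compound 1 gives > 100000 nM, which is a limit of the assay rather than a number. Among the three values shown, (the limit of > 100000 nM in this assay, at which 1 of the 3 values shown sits). Two further compounds have numbers: compound 2 `O=S(=O)(Nc1ccc(-c2nc3ccccc3o2)cc1)c1ccc(F)c(C(F)(F)F)c1` gives 28000 nM in this assay, and compound 3 `O=S(=O)(Nc1ccc2oc(-c3ccccc3)nc2c1)c1ccc(F)c(C(F)(F)F)c1`, which shares the same core, gives 69000 nM. Compound 4 `O=S(=O)(Nc1ccc2oc(-c3ccccc3)nc2c1)c1ccccc1F` is not yet measured; it differs from compound 1 in one place: 2-fluorophenyl in place of 4-methylphenyl on a sulfonyl sulfur. Among the measured compounds shown here, no measured pair maps this change directly, so the size of the step can only be judged from the neighbours. Since compound 3 gives 69000 nM with another substituted phenyl on the same sulfur, compound 4 is expected to land in a similar region of weak inhibition. The step of an at least 1.1-fold lower number from compound 1 to compound 4 (0.04 log units; that floor lies within the scatter) is expected to be small, possibly none beyond the scatter. The limit on compound 1 leaves its direction open. Compound 4 is therefore estimated at 90000 nM, between 30000 nM and 300000 nM, with a fair chance that this assay returns only a limit.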

Compound 4, half-maximal inhibitory concentration: > 100000 nM
Compound 4 ended at the assay's limit (the forecaster's own chance of this, stated with the estimate: 55%); middle value at least 1.1-fold (0.04 log units) from the limit.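

Among the compounds shown here, compound 1 and compound 4 both end at a limit of this assay, so no step between them can be read: the limit of > 100000 nM in this assay, at which 2 of the 4 values shown sit. The compounds shown leave open whether 2-fluorophenyl and 4-methylphenyl on a sulfonyl sulfur differ at all in this assay.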